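A few compounds are considered here, and "the series" means these few. Any claim that something is new, unique, unknown or untested is made for them only; others in the source may bear on it.

The measured compounds and their numbers:

Compound 1 `Clc1ccc(Sc2c(-c3ccc(Br)cc3)[nH]c3ccccc23)cc1` gives 26000 nM in a functional assay on A549 cells (Homo sapiens) for inhibition, read by MTT assay, with a stated time of 72 h; a lower number here means a stronger inhibitor of growth, a higher number a weaker inhibitor of growth.
Compound 2 `CCOC(=O)c1ccc2[nH]c(-c3ccc(Cl)cc3)c(Oc3ccc(Cl)cc3)c2c1` gives 28000 nM in this assay.
Compound 3 `O=C(COc1ccc(Cl)cc1)Nc1c(-c2ccccc2)[nH]c2ccccc12` gives 37000 nM in this assay.

The three numbers sit close together. The value of compound 2 lies between those of compound 1 and compound 3, and its gap to each of them is within the usual scatter of repeated measurements, so the three compounds cannot be told apart on these numbers: none of them can be called the stronger or the weaker growth inhibitor.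

Compound 4 `COc1ccc2[nH]c(-c3ccc(Cl)cc3)c(Oc3ccc(Cl)cc3)c2c1` has not yet been measured. It shares its core with compound 2 and differs from it in one place: methoxy in place of ethoxycarbonyl on an aromatic carbon. Among the compounds with values here, no two measured compounds differ from each other in just one place, so there is no measured step that shows how such a swap has moved the number before. With nothing more to go on than the three close values, the step expected from compound 2 to compound 4 in this assay is a 1.1-fold higher number from compound 2 to compound 4 (0.03 log units; within the scatter), that is, no change beyond the scatter in either direction. On that basis compound 4 is estimated at 30000 nM, with a range from 12000 nM to 80000 nM.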

Compound 4, concentration for 50% growth inhibition: 59000 nM
For compound 4 the middle estimate is 2.0-fold (0.29 log units) below the measured one; measured number inside the range.
By their numbers in this assay, from the lowest: compounds 1, 2, 3 and 4 (each within the scatter of the next, the first and the last beyond it).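

Within the data shown here, this pair gives the first direct reading of this position, since no earlier compounds differed in only one place. In this assay, placing methoxy in place of ethoxycarbonyl on this aromatic carbon gives a 2.1-fold higher number from compound 2 to compound 4 (0.32 log units; beyond the scatter), a modest move towards weaker growth inhibition, so the number does respond to what sits here. The swap changes several things at once, however, as it removes the carbonyl and replaces a five-heavy-atom group with a two-heavy-atom one, and no measurement at hand shows which of these differences moved the number.

The compounds shown leave open how a carboxylic acid, an amine or a plain hydrogen on this same carbon would compare, and such groups would help to show whether the carbonyl or simply the length of the group is what counts. They also leave open whether the same swap would produce a step of similar size and direction on another core, as this single pair speaks only for the core shared by compound 2 and compound 4.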